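Benzyl Isothiosemicarbazone on a Methoxyanilino Core

The source may hold more compounds than are shown below. What is called first, only, known or untested is meant among the compounds shown, and "the series" means these compounds.

Three compounds from this series have numbers in a functional assay on HCT-116 cells (Homo sapiens) for antiproliferative activity, read by MTT assay, with a stated time of 72 h; a higher number here means a weaker inhibitor, a lower number a stronger inhibitor. Compound 1 `Cc1ccc(NC2=C/C(=N/NC(N)=S)C(=O)N=C2Nc2ccc(C)cc2)cc1` gives 7040 nM in this assay. Compound 3 `Cc1ccc(NC2=C/C(=N/N=C(\N)SCc3ccccc3)C(=O)N=C2Nc2ccc(C)cc2)cc1` carries a different group on the double-bonded nitrogen and gives 8270 nM in this assay. The change from compound 1 to compound 3 is a group of 11 heavy atoms (8 carbon, 2 nitrogen, 1 sulfur; one six-membered aromatic ring of carbon only) in place of a group of 4 heavy atoms (1 carbon, 2 nitrogen, 1 sulfur; no ring), on a double-bonded nitrogen, and the step it made was a 1.2-fold higher number from compound 1 to compound 3 (0.07 log units; within the scatter), so the two numbers cannot be told apart.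

Compound 2 `COc1ccccc1NC1=C/C(=N/NC(N)=S)C(=O)N=C1Nc1ccccc1OC` rests on a different core; how that core differs from the core of compound 1 is not broken down here. In this assay compound 2 gives 20800 nM, the highest of the three numbers, beyond the scatter from both compound 3 and compound 1.

Compound 4 `COc1ccccc1NC1=C/C(=N/N=C(\N)SCc2ccccc2)C(=O)N=C1Nc1ccccc1OC` has not yet been measured in this assay. It stands to compound 2 as compound 3 stands to compound 1: the change is a group of 11 heavy atoms (8 carbon, 2 nitrogen, 1 sulfur; one six-membered aromatic ring of carbon only) in place of a group of 4 heavy atoms (1 carbon, 2 nitrogen, 1 sulfur; no ring), on a double-bonded nitrogen, the same change at the same kind of place. Because a 1.2-fold higher number from compound 1 to compound 3 (0.07 log units; within the scatter) lay within the scatter, the step expected from compound 2 to compound 4 is estimated as a 1.2-fold higher number from compound 2 to compound 4 (0.06 log units; within the scatter), a small one that rests on a single precedent. The number expected for compound 4 in this assay is therefore 24000 nM, with a range estimated from 11000 nM to 52000 nM.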

Compound 4, half-maximal inhibitory concentration: 14500 nM
For compound 4 the middle estimate is 1.7-fold (0.22 log units) above the measured one; the range from low to high includes it.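

In this assay, the group of 11 heavy atoms with its six-membered aromatic ring, placed on the double-bonded nitrogen in place of the group of 4 heavy atoms, gave a 1.4-fold lower number from compound 2 to compound 4 (0.16 log units; within the scatter). Set beside the earlier step, the same change gives no difference that can be told apart between the two cores: the same change on two cores in this assay, a 1.2-fold higher number (0.07 log units; within the scatter) from compound 1 to compound 3 and a 1.4-fold lower number (0.16 log units; within the scatter) from compound 2 to compound 4, 1.7-fold (0.23 log units) apart, within the scatter of two such steps

Among these compounds, this shows that, on these two cores, the swap left the number within the scatter each time and that its outcome on one core agreed with its outcome on the other, but it rests on only two pairs of compounds, does not show that the change would stay this small on any further core, and gives no reason for the result.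

The compounds shown leave open whether a methyl group, a longer chain or an amine-bearing chain in place of the benzyl group would behave in the same way. They also leave open whether the change would carry over to a core with chlorine or a nitrile in place of the methyl and methoxy groups of the two cores seen here.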